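The source may hold more compounds than are shown below. What is called first, only, known or untested is meant among the compounds shown, and "the series" means these compounds.

Compound 3 `NC(=O)c1ccccc1NC(=O)c1cn(-c2ccccc2)nc1-c1ccccc1` gives 14.4% in a functional assay on the whole organism (strain albino) for inhibition, with Rattus norvegicus as the target, read by paw edema, with stated times of 30 min and 3 h, at a dose of 50 mg/kg by the oral route (a lower number here means less inhibition, a higher number more inhibition at the dose given (going by the name of the read-out)), the second highest of the three numbers recorded. Its nearest neighbour is compound 1 `O=C(O)CCC(=O)/C=C/c1cn(-c2ccccc2)nc1-c1ccccc1`, which gives 15.5% in this assay, a gap within the scatter, and compound 2 `O=C(O)CCC(=O)/C=C/c1cn(-c2ccccc2)nc1-c1ccc(Cl)cc1`, which gives 6.32% in this assay, lies furthest from it, also within the scatter. Compound 4 `NC(=O)c1ccccc1NC(=O)c1cn(-c2ccccc2)nc1-c1ccc(Cl)cc1` differs from compound 3 by chloro in place of hydrogen on an aromatic carbon. Among the compounds with values here, one measured step bears directly on this change: a number 9.2 percentage points lower from compound 1 to compound 2 (within the scatter). On that basis compound 4 is expected to show no movement beyond the scatter in this assay, with only a small downward drift estimated as a number 6.4 percentage points lower from compound 3 to compound 4 (within the scatter). Compound 4 is therefore estimated at 8%, within a range from 0% to 18%.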

Compound 4, a percentage reported as inhibition, in the whole organism at one dose (the size of the read-out at that dose, not a potency): 3.45%
For compound 4 the middle estimate is 4.6 percentage points above the measured one; the measured number falls inside the stated range.
By their numbers in this assay, from the lowest: compounds 4, 2, 3 and 1 (each within the scatter of the next, the first and the last beyond it).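

In this assay, chloro in place of hydrogen on the aromatic carbon para to a large group gives a number 11 percentage points lower from compound 3 to compound 4 (beyond the scatter), so on this core the change passes the scatter, if only modestly. The change now stands on two cores, and it points the same way on both: the same change on two cores in this assay, a number 9.2 percentage points lower (within the scatter) from compound 1 to compound 2 and a number 11 percentage points lower (beyond the scatter) from compound 3 to compound 4, 1.8 percentage points apart, within the scatter of two such steps

The compounds shown leave open whether the downward step belongs to chloro alone or would also follow from another group at this position, such as fluoro, methoxy or an amine.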